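Aniline Variation on a Diterpenoid Butenolide Scaffold

A few compounds are considered here, and "the series" means these few. Any claim that something is new, unique, unknown or untested is made for them only; others in the source may bear on it.

Measured compounds:
compound 1 `C=C1[C@@H](OC(C)=O)C[C@@H]2[C@](C)(CO[Si](C)(C)C(C)(C)C)[C@H](OC(C)=O)CC[C@@]2(C)[C@@H]1C[C@@H](Nc1ccccc1)C1=CCOC1=O` — 4500 nM
compound 2 `C=C1[C@@H](C/C=C2/C(=O)OC[C@H]2OC(C)=O)[C@]2(C)CC[C@@H](OC(C)=O)[C@@](C)(CO[Si](C)(C)C(C)(C)C)[C@H]2C[C@@H]1O` — 6850 nM
compound 3 `C=C1[C@@H](OC(C)=O)C[C@@H]2[C@](C)(COC=O)[C@H](OC(C)=O)CC[C@@]2(C)[C@@H]1C[C@@H](Nc1ccc(Br)cc1)C1=CCOC1=O` — 15900 nM

In a functional assay on A549 cells (Homo sapiens) for cytotoxicity, read by sulforhodamine B assay (on this read-out higher numbers stand for weaker inhibition and lower numbers for stronger inhibition), compound 3 gives 15900 nM, the highest of the three numbers. Compound 2 stands nearest to it with 6850 nM, a gap beyond the scatter, and compound 1 stands furthest with 4500 nM, also beyond the scatter. Compound 3 is thus the weakest inhibitor of the three in this assay.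

Compound 4 `C=C1[C@@H](OC(C)=O)C[C@@H]2[C@](C)(COC=O)[C@H](OC(C)=O)CC[C@@]2(C)[C@@H]1C[C@@H](Nc1ccccc1C(=O)O)C1=CCOC1=O` is the next step. Its structure differs from compound 3 in one place: 2-carboxyphenyl in place of 4-bromophenyl on an amine nitrogen. Among the compounds with values here, no comparable change has been measured within this set, so there is no step to lean on; only the single value of compound 3 anchors the expectation.

With the aniline ring altered in this way, the author expects compound 4 to stay close to compound 3 in this assay, with a step of a 1.1-fold higher number from compound 3 to compound 4 (0.05 log units; within the scatter) that is expected to be small and uncertain in direction. The estimate for compound 4 in this assay is therefore 18000 nM, with a range from 6000 nM to 55000 nM.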

Compound 4, half-maximal inhibitory concentration: 45900 nM
For compound 4 the middle estimate is 2.6-fold (0.41 log units) below the measured one, within the range that was stated.
By their numbers in this assay, from the lowest: compounds 1 and 2 (each within the scatter of the next); then compound 3; then compound 4.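

The aryl group on the amine nitrogen is not a silent position in this assay: with the rest of the molecule unchanged, 2-carboxyphenyl in place of 4-bromophenyl gives a 2.9-fold higher number from compound 3 to compound 4 (0.46 log units; beyond the scatter), a modest step towards weaker inhibition and beyond the scatter. This is the only single-place comparison among the compounds shown, so it is the first direct reading of this position. The entering group carries a hydrogen-bond donor and a hydrogen-bond acceptor that the leaving group lacks, but no supporting measurement shows what lies behind the step.

The compounds shown leave open whether the step follows the loss of bromine or the arrival of the carboxylic acid. Equally open, as far as these compounds go, is how a methyl ester or a primary amide in place of that acid would read on the same core.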